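The source may report more compounds than this note shows. Statements on the series, on what has been measured and on what is new or still open speak of the compounds shown alone.

In a functional assay on SF-295 cells (Homo sapiens) for cytotoxicity (on this read-out lower numbers stand for stronger inhibition of growth and higher numbers for weaker inhibition of growth), three compounds of one family have been measured. Compound 1 `OCCCCC#Cc1ccccc1C#Cc1cccc(O)c1` gives 21000 nM. Compound 2 `OCCCCC#Cc1ccccc1C#Cc1cccc(C(F)(F)F)c1` gives 16500 nM. Compound 3 `OCCCCC#Cc1ccccc1C#Cc1ccc(O)cc1` gives 16200 nM. All three numbers lie close together: the steps from compound 1 are a 1.3-fold lower number from compound 1 to compound 2 (0.10 log units; within the scatter) and a 1.3-fold lower number from compound 1 to compound 3 (0.11 log units; within the scatter), and compound 2 and compound 3 are separated by even less, so no order among the three can be read from these values.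

Compound 4 `OCCCCC#Cc1ccccc1C#Cc1ccc(C(F)(F)F)cc1` has not yet been measured. It differs from compound 3 as follows: trifluoromethyl in place of hydroxy on an aromatic carbon. The same kind of change has already been made once, from compound 1 to compound 2: trifluoromethyl in place of hydroxy on an aromatic carbon. The two cores on which it is made differ as told by 4-hydroxyphenyl in place of 3-hydroxyphenyl on a triple-bonded carbon, and so the surroundings of the change are not the same word for word: in compound 1 the group sits meta to a large group, whereas in compound 3 it sits para to a large group. The change is therefore the same kind of change, not the same change.

Its one measured outcome was a 1.3-fold lower number from compound 1 to compound 2 (0.10 log units; within the scatter), a step within the scatter. Resting on that single step and on the closeness of compound 3 to compound 2 at 16500 nM, compound 4 is expected to show a step of about a 1.2-fold lower number from compound 3 to compound 4 (0.10 log units; within the scatter) in this assay. Compound 4 is therefore estimated at 13000 nM, with a likely range from 6000 nM to 30000 nM, though it should be noted that a single prior step on a different core gives this expectation only limited footing.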

Compound 4, concentration for 50% growth inhibition: 19100 nM
Compound 4: middle estimate off by 1.5-fold (0.17 log units), on the low side, within the range that was stated.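

In this assay, trifluoromethyl in place of hydroxy on the core of compound 3, para to a large group, gave a 1.2-fold higher number from compound 3 to compound 4 (0.07 log units; within the scatter), so this second use of the change stayed within the scatter, as the first had on the core of compound 1. The two steps cannot be told apart either, and no difference between the cores can be read from them: the same change on two cores in this assay, a 1.3-fold lower number (0.10 log units; within the scatter) from compound 1 to compound 2 and a 1.2-fold higher number (0.07 log units; within the scatter) from compound 3 to compound 4, 1.5-fold (0.18 log units) apart, within the scatter of two such steps. This shows that on these two cores the exchange of hydroxy for trifluoromethyl made no readable difference in this assay, so the absence of an effect carried over from one core to the other; it does not show that the change has any effect of its own, that its position matters, or that the same would hold on any third core.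

The compounds shown leave open whether a different group on the same aromatic carbon, such as an amine or a carboxylic acid, would give a step beyond the scatter in this assay. They also leave open whether a longer chain in place of the one that ends in hydroxy would separate these numbers.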